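The compounds below may be only part of what the source reports. "The series", "measured", "known", "first", "only" and "open" are said of these compounds alone.

Compound 1 `O=C(N/N=C/c1ccc(F)cc1)Nc1ccc(Oc2ccnc3[nH]ccc23)c(F)c1`: 3880 nM
Compound 2 `O=C(N/N=C/c1ccc([N+](=O)[O-])cc1)Nc1ccc(Oc2ccnc3[nH]ccc23)c(F)c1`: 3030 nM

In a functional assay on HepG2 cells (Homo sapiens) for antiproliferative activity, read by MTT assay, with a stated time of 72 h (on this read-out lower numbers stand for stronger inhibition and higher numbers for weaker inhibition), compound 2 gives 3030 nM. The measured step, a 1.3-fold lower number from compound 1 to compound 2 (0.11 log units; within the scatter), lies within the usual scatter of repeat measurements, so compound 2 stands level with compound 1 on these numbers.

The compound still to be measured is compound 3 `O=C(N/N=C/c1ccc(Cl)c(Cl)c1)Nc1ccc(Oc2ccnc3[nH]ccc23)c(F)c1`, which keeps the shared core and changes one group: 3,4-dichlorophenyl in place of 4-nitrophenyl on a carbon with a double bond to nitrogen. In short, this is 3,4-dichlorophenyl in place of 4-nitrophenyl on a carbon with a double bond to nitrogen.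

Among the measured compounds shown here, only one measured step bears on this change. The expectation rests on a 1.3-fold lower number from compound 1 to compound 2 (0.11 log units; within the scatter), a swap of fluoro for nitro on an aromatic carbon, which stayed within the scatter. For the measured compounds named here, that is thin evidence, as no compound with two chlorine atoms has been measured and the data favour no direction. No step beyond the scatter is therefore expected in this assay. The expected change is a 1.0-fold lower number from compound 2 to compound 3 (0.00 log units; within the scatter). For compound 3 the estimated value is 3000 nM, with an expected range of 1300 nM to 7000 nM.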

Compound 3, half-maximal inhibitory concentration: 3700 nM
Beside the measured number, compound 3's estimate is 1.2-fold (0.09 log units) below it, and the stated range covers the measured number.
By their numbers in this assay, from the lowest: compounds 2, 3 and 1 (each within the scatter of the next).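

In this assay the swap of 4-nitrophenyl for 3,4-dichlorophenyl on a carbon with a double bond to nitrogen stays within the scatter (a 1.2-fold higher number from compound 2 to compound 3 (0.09 log units; within the scatter)), and so does the comparison with the 4-fluorophenyl compound (a 1.0-fold lower number from compound 1 to compound 3 (0.02 log units; within the scatter)). The earlier compounds shown here offered a single comparison, fluoro against nitro on the same aromatic ring, whereas compound 3 adds a third group and two further comparisons, so all three compounds now stand level and no step at this position goes beyond the scatter. Nothing available explains why these three groups read alike.

On these data alone, it remains open whether this level picture holds for groups of a different kind at this position, such as a phenyl ring carrying an amine or a carboxylic acid, or a longer chain in place of the aromatic ring. All three numbers also come from a single assay on one type of cell, so they cannot show whether the three compounds would stay level in any other test.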